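A few compounds are considered here, and "the series" means these few. Any claim that something is new, unique, unknown or untested is made for them only; others in the source may bear on it.

Compound 3 `C=CCN(Cc1cccs1)C(=O)COc1ccc(C)cc1` stands lowest of the three numbers recorded so far in an assay on HEK293 cells for agonist activity at transient receptor potential cation channel subfamily M member 8 (Homo sapiens), read by fluorescence and calcium flux, with a stated time of 15 min (on this read-out higher numbers stand for an effect only at larger amounts of compound and lower numbers for an effect already at smaller amounts), where compound 3 gives 20 nM. Its nearest neighbour is compound 2 `Cc1ccc(OCC(=O)N(Cc2cccs2)CC(C)C)cc1`, for which this assay records 900 nM, and the furthest is compound 1 `Cc1ccc(OCC(=O)N(Cc2cccs2)c2cnn(C)c2)cc1`, with 63000 nM in this assay. Compound 4 `Cc1ccc(OCC(=O)N(Cc2cccs2)c2ccn[nH]2)cc1` differs from compound 3 on the amide-type nitrogen: 1H-pyrazol-5-yl in place of allyl on an amide-type nitrogen. The step that bears most directly on this change is a 3200-fold lower number from compound 1 to compound 3 (3.50 log units; beyond the scatter), since it likewise exchanges an allyl for an aromatic pyrazolyl ring on the same nitrogen, though with a different attachment point and a methyl on the ring. The step of a 70-fold lower number from compound 1 to compound 2 (1.85 log units; beyond the scatter) points the same way, while a 45-fold lower number from compound 2 to compound 3 (1.65 log units; beyond the scatter) concerns only the saturated chain and does not involve a ring. A large rise in the number is therefore expected for compound 4, roughly a 1000-fold higher number from compound 3 to compound 4 (3.00 log units; beyond the scatter). In this assay compound 4 is estimated at 20000 nM, within a range from 3000 nM to 100000 nM.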

Compound 4, half-maximal effective concentration: 0.2 nM
Compound 4: the middle estimate sits 100000-fold (5.00 log units) above what was measured; measured number outside the range, below it.
By their numbers in this assay, from the lowest: compound 4; then compound 3; then compound 2; then compound 1.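

Compound 4 shows that an aromatic ring on the amide-type nitrogen need not raise the number: in this assay, 1H-pyrazol-5-yl in place of allyl gives a 100-fold lower number from compound 3 to compound 4 (2.00 log units; beyond the scatter), and in place of isobutyl it gives a 4500-fold lower number from compound 2 to compound 4 (3.65 log units; beyond the scatter). Among the compounds shown here, the earlier compounds held only one ring at this place, and the exchange of that 1-methyl-1H-pyrazol-4-yl for 1H-pyrazol-5-yl gives a 320000-fold lower number from compound 1 to compound 4 (5.50 log units; beyond the scatter), so the two pyrazole groups stand at opposite ends of the series. No measurement at hand accounts for this gap.

The compounds shown leave open whether 1H-pyrazol-4-yl or 1-methyl-1H-pyrazol-5-yl would stand nearer compound 4 or compound 1, which would separate the methyl from the choice of ring carbon. They also leave open how a phenyl or pyridyl ring would behave on this nitrogen.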